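The compounds below may be only part of what the source reports. "The series", "measured", "known", "first", "only" and "open" are said of these compounds alone.

Measured in a functional assay on A549 cells (Homo sapiens) for inhibition, read by MTT assay, with a stated time of 24 h; a higher number here means a weaker inhibitor, a lower number a stronger inhibitor:
- compound 1 `CC1(C)[C@H]2CC[C@]1(C)N(Cc1cn(-c3ccc(C#N)cc3)nn1)C(=O)C2`: 140 nM
- compound 2 `CC1(C)[C@H]2CC[C@]1(C)N(Cc1cn(-c3cccc(C#N)c3)nn1)C(=O)C2`: 440 nM
- compound 3 `CC1(C)[C@H]2CC[C@]1(C)N(Cc1cn(-c3ccccc3F)nn1)C(=O)C2`: 240 nM

In this assay, compound 3 gives 240 nM, a number within the scatter of both others: a 1.7-fold higher number from compound 1 to compound 3 (0.23 log units; within the scatter), and a 1.8-fold lower number from compound 2 to compound 3 (0.26 log units; within the scatter). Only compound 1 and compound 2 are separated beyond the scatter, with a 3.1-fold higher number from compound 1 to compound 2 (0.50 log units; beyond the scatter).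

The next compound, compound 4 `CC1(C)[C@H]2CC[C@]1(C)N(Cc1cn(-c3ccc(F)cc3)nn1)C(=O)C2`, keeps the shared core and changes one group: 4-fluorophenyl in place of 2-fluorophenyl on an aromatic nitrogen. For the measured compounds named here, no measured pair makes this exchange directly. The closest parallel is the modest step between the two cyanophenyl compounds, a 3.1-fold higher number from compound 1 to compound 2 (0.50 log units; beyond the scatter), where 4-cyanophenyl carries the lower number. That single pair involves a different group, so it supports only a slight lean towards a lower number for 4-fluorophenyl. The small steps to compound 3, a 1.7-fold higher number from compound 1 to compound 3 (0.23 log units; within the scatter), also argue against expecting a large change.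

The expected step is a 1.2-fold lower number from compound 3 to compound 4 (0.08 log units; within the scatter), an estimate that stays within the scatter in this assay. For compound 4 the estimated value is 200 nM, with an expected range from 90 nM to 450 nM.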

Compound 4, half-maximal inhibitory concentration: 230 nM
The estimate for compound 4 lay 1.2-fold (0.06 log units) below the measured number, and the stated range covers the measured number.
By their numbers in this assay, from the lowest: compounds 1, 4, 3 and 2 (each within the scatter of the next, the first and the last beyond it).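

In this assay, the exchange of 2-fluorophenyl for 4-fluorophenyl on the aromatic nitrogen gives a 1.0-fold lower number from compound 3 to compound 4 (0.02 log units; within the scatter). With the same atoms joined differently, this pair shows no readable effect of where the fluorine sits on the phenyl group, whereas the two cyanophenyl compounds do stand apart, with a 3.1-fold higher number from compound 1 to compound 2 (0.50 log units; beyond the scatter). Compound 4 also lies within the scatter of both cyano compounds, with a 1.6-fold higher number from compound 1 to compound 4 (0.22 log units; within the scatter) and a 1.9-fold lower number from compound 2 to compound 4 (0.28 log units; within the scatter), so neither exchange separates fluoro from cyano, and no supporting measurement is available to explain these numbers.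

The phenyl groups shown carry only fluoro or cyano, so it remains open whether an amine, a carboxylic acid or a methoxy group on the phenyl group would move the number beyond the scatter. As far as these compounds go, it is equally open whether the number would hold if a longer alkyl chain took the place of the whole phenyl group on the aromatic nitrogen.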